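This account rests on a few compounds, and the source may have more. Where it says the series, first, only, none or still open, it means among the compounds named here.

For the measured compounds named here, the three compounds measured so far share one core and differ in the group on an aromatic nitrogen and in the ring attached to the core. In a functional assay for antagonist activity at corticotropin-releasing factor receptor 1 (Rattus norvegicus) (a higher number here means a weaker inhibitor, a lower number a stronger inhibitor), compound 1 `CCC(C1CC1)n1c(=O)c(C)nc2c(-c3cc(C)c(Cl)cc3OC)ccnc21` gives 1.1 nM. Compound 2 `COc1ccc(-c2ncnc3c2nc(C)c(=O)n3C(C2CC2)C2CC2)c(C)c1` gives 37 nM in this assay. Compound 3 `CCCC(C1CC1)n1c(=O)c(C)nc2c(-c3ccc(Cl)cc3Cl)ccnc21` gives 4.3 nM in this assay, the second highest of the three numbers: compound 1 sits nearest with a lower number, and compound 2 lies furthest away with a higher number, both gaps beyond the usual scatter. Compound 4 `CC[C@@H](COC)n1c(=O)c(C)nc2c(-c3ccc(Cl)cc3Cl)ccnc21` has not yet been measured. It keeps the ring of compound 3 and alters only the side chain: 1-(methoxymethyl)propyl in place of 1-cyclopropylbutyl on an aromatic nitrogen. A branched chain carrying a three-membered ring is thus replaced by a branched chain with an oxygen in it. Going by the values given here, no measured pair shows this exact swap, so the expectation rests on compound 3 alone. Because compound 3 gives 4.3 nM, compound 4 is expected to stay in the same region, with a step of a 1.4-fold higher number from compound 3 to compound 4 (0.14 log units; within the scatter) expected in this assay, a modest rise that may not exceed the scatter. Compound 4 is therefore estimated at 6 nM, within a range from 2 nM to 20 nM.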

Compound 4, half-maximal inhibitory concentration: 74 nM
The estimate for compound 4 lay 12-fold (1.09 log units) below the measured number, and the stated range ends below it.
By their numbers in this assay, from the lowest: compound 1; then compound 3; then compounds 2 and 4 (each within the scatter of the next).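

In this assay, exchanging 1-cyclopropylbutyl for 1-(methoxymethyl)propyl on the aromatic nitrogen, with the dichlorophenyl ring held fixed, gives a 17-fold higher number from compound 3 to compound 4 (1.24 log units; beyond the scatter). The earlier compounds shown here differ in this side chain and in the attached ring at once, so they could not show what the side chain does alone; this pair shows that this position by itself can produce a large change in inhibitor strength, and that a side chain of similar size is not automatically a safe replacement. No measurement available here bears on why the number rose.

The swap changes several things together, removing the three-membered ring, adding an oxygen and altering the atom count, and the shown compounds cannot separate these contributions, nor can they show whether the mirror-image form of the defined stereocentre would behave in the same way. A side chain that keeps the cyclopropyl ring while carrying the methoxy group, or an open-chain hydrocarbon such as 1-ethylbutyl on the same nitrogen, would help to show which of these changes matters.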